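A pyrazole change on the weaker of two compounds

The source may report more compounds than this note shows. Statements on the series, on what has been measured and on what is new or still open speak of the compounds shown alone.

In a functional assay on NCI-H1993 cells (Homo sapiens) for inhibition, read by CCK-8 assay, with a stated time of 72 h (on this read-out higher numbers stand for weaker inhibition and lower numbers for stronger inhibition), compound 1 (`CC(NC/N=C/c1cnn(C)c1)c1ccc2ncccc2c1`) gives 197 nM, while compound 2 (`CC(NC/N=C/c1ccnn1C)c1ccc2ncccc2c1`) gives 3290 nM, the higher of the two numbers. Among the measured compounds shown here, the only measured step, a 17-fold higher number from compound 1 to compound 2 (1.22 log units; beyond the scatter), puts 1-methyl-1H-pyrazol-5-yl in place of 1-methyl-1H-pyrazol-4-yl and lies beyond the scatter. Compound 3 (`CC(NC/N=C/c1cn[nH]c1)c1ccc2ncccc2c1`), not yet measured, has 1H-pyrazol-4-yl in place of 1-methyl-1H-pyrazol-5-yl on a carbon with a double bond to nitrogen. For the measured compounds named here, the change thus returns to a pyrazol-4-yl group like that of compound 1, but without the methyl, and no measured step isolates the loss of that methyl. Most of the measured step is therefore expected to reverse. The expected result is an 11-fold lower number from compound 2 to compound 3 (1.04 log units; beyond the scatter), a large move towards stronger inhibition. Compound 3 is estimated at 300 nM, with an expected range of 80 nM to 1200 nM.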

Compound 3, half-maximal inhibitory concentration: 519 nM
For compound 3 the middle estimate is 1.7-fold (0.24 log units) below the measured one; the range from low to high includes it.
By their numbers in this assay, from the lowest: compound 1; then compound 3; then compound 2.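

Returning to a pyrazol-4-yl group at this position, on the carbon with a double bond to nitrogen, recovers much of what the 1-methyl-1H-pyrazol-5-yl group lost in this assay, with a 6.3-fold lower number from compound 2 to compound 3 (0.80 log units; beyond the scatter) in that assay. The methyl on the aromatic nitrogen also has a measurable part of its own: hydrogen in its place gives a 2.6-fold higher number from compound 1 to compound 3 (0.42 log units; beyond the scatter) and lies beyond the scatter, though this step is smaller than a 17-fold higher number from compound 1 to compound 2 (1.22 log units; beyond the scatter) for the change to 1-methyl-1H-pyrazol-5-yl. No evidence is available to explain either difference.

The compounds shown leave open how an ethyl group or a longer chain ending in an amine would compare with methyl on that nitrogen. They also do not show whether a 1H-pyrazol-5-yl group would behave like its methylated counterpart, which would separate the effect of the attachment point from that of the methyl.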